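A few compounds are considered here, and "the series" means these few. Any claim that something is new, unique, unknown or untested is made for them only; others in the source may bear on it.

Working notes on the series.

The three measured compounds share one backbone and differ only in the group on the saturated chain carbon bound to the carbonyl. Compound 1 `CC(C)[C@H](NC(=O)COc1cccc2ccccc12)C(=O)N[C@@H](CC(=O)O)C(=O)CSc1nc(-c2ccccc2)c(-c2ccccc2)[nH]1` carries a diphenylimidazolyl sulfide; compound 2 `CC(C)[C@H](NC(=O)COc1cccc2ccccc12)C(=O)N[C@@H](CC(=O)O)C(=O)CSc1nc(-c2ccccc2)c(-c2ccccc2)o1` the corresponding oxazole; compound 3 `CC(C)[C@H](NC(=O)COc1cccc2ccccc12)C(=O)N[C@@H](CC(=O)O)C(=O)CSc1nc2ccccc2s1` a benzothiazole sulfide.

In a functional assay on Jurkat cells (Homo sapiens) for inhibition (on this read-out higher numbers stand for weaker inhibition and lower numbers for stronger inhibition), compound 1 gives > 200000 nM, which is a limit of the assay and not a number. In this assay compound 2 gives > 200000 nM, likewise a limit. In this assay compound 3 gives > 200000 nM, again a limit. For the measured compounds named here, compound 3 therefore stands nowhere distinguishable from compound 1 or compound 2: all three sit at the limit of > 200000 nM in this assay, at which 3 of the 3 values shown sit, and no step between measured compounds can be sized.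

Compound 4 `CC(C)[C@H](NC(=O)COc1cccc2ccccc12)C(=O)N[C@@H](CC(=O)O)C(=O)COc1[nH]cnc2nncc1-2` is the next point. Relative to compound 3 the change is a group of 10 heavy atoms (5 carbon, 4 nitrogen, 1 oxygen; one five-membered aromatic ring with 2 hetero atoms, one six-membered aromatic ring with 2 hetero atoms) in place of a group of 10 heavy atoms (7 carbon, 1 nitrogen, 2 sulfur; one five-membered aromatic ring with 2 hetero atoms, one six-membered aromatic ring of carbon only), on a saturated chain carbon bound to a carbonyl carbon. Going by the values given here, no measured step informs this change, and the three limits give no direction. The expectation for the step from compound 3 to compound 4 in this assay is a number no higher from compound 3 to compound 4 (the limit leaves the size open), which is to say none resolvable beyond the scatter. Compound 4 is accordingly estimated in this assay at 200000 nM, within 40000 nM to 1000000 nM, with a further limit the most probable outcome.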

Compound 4, half-maximal inhibitory concentration: 161000 nM
Compound 4: middle estimate off by 1.2-fold (0.09 log units), on the high side; measured number inside the range.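

In this assay compound 4 is the first compound shown with a number and not a limit, so the group on the saturated chain carbon bound to a carbonyl carbon can now be compared against a measured value, though only on one side. Putting the nitrogen-rich group of 10 heavy atoms in place of (1,3-benzothiazol-2-yl)sulfanyl gives an at least 1.2-fold lower number from compound 3 to compound 4 (0.09 log units; that floor lies within the scatter), so no change beyond the scatter is shown. The steps among the other compounds cannot be read, and the series remains at or near the limit: the limit of > 200000 nM in this assay, at which 3 of the 4 values shown sit.

From the compounds shown here alone, it remains open whether the oxygen link or the ring atoms of the entering group carry any part of this step. Also open, going by these compounds, is whether a simple group such as phenoxy or 2,3,5,6-tetrafluorophenoxy at this place would give a number clearly lower in this assay.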